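The source may report more compounds than this note shows. Statements on the series, on what has been measured and on what is new or still open speak of the compounds shown alone.

Compound 2 `COc1ccc2[nH]c(C(=O)N3CC(=O)N(Cc4ccccc4)[C@@H](CN4CC5CCCCC5C4)C3)cc2c1` shares its core with compound 1 `COc1ccc2[nH]c(C(=O)N3CC(=O)N(Cc4ccccc4)[C@@H](CN4CCN(c5ccccn5)CC4)C3)cc2c1`; the two differ only in the group carried on a saturated chain carbon bound to a saturated ring carbon. In a physicochemical assay for solubility, read by spectrophotometry, in phosphate buffer, with a stated time of 2 h, at pH 7.4 (a lower number here means a less soluble compound, a higher number a more soluble compound), compound 1 gives 30200 nM, and in this assay compound 2 gives 23800 nM. The step between them, a 1.3-fold lower number from compound 1 to compound 2 (0.10 log units; within the scatter), is within the scatter, so on the numbers shown compound 2 stands side by side with compound 1 rather than apart from it.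

Compound 3 `COc1ccc2[nH]c(C(=O)N3CC(=O)N(Cc4ccccc4)[C@@H](CN4CCn5cccc5C4)C3)cc2c1` is not yet measured in this assay. The change from compound 2 to compound 3 is a group of 9 heavy atoms (7 carbon, 2 nitrogen; one five-membered aromatic ring with 1 hetero atom, one six-membered non-aromatic ring with 2 hetero atoms) in place of a group of 9 heavy atoms (8 carbon, 1 nitrogen; one five-membered non-aromatic ring with 1 hetero atom, one six-membered non-aromatic ring of carbon only), on a saturated chain carbon bound to a saturated ring carbon. Going by the values given here, only one measured step bears on such a swap at that place, the step of a 1.3-fold lower number from compound 1 to compound 2 (0.10 log units; within the scatter), and it was within the scatter even though the group exchanged there was larger. The expectation for compound 3 in this assay is therefore no step beyond the scatter, with the direction left open, because compound 1 gives 30200 nM and compound 2 gives 23800 nM across a comparable exchange. Compound 3 is thus expected to give about 27000 nM in this assay, with a range from 13000 nM to 55000 nM. That estimate corresponds to an expected step of a 1.1-fold higher number from compound 2 to compound 3 (0.05 log units; within the scatter).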

Compound 3, solubility: 29700 nM
Compound 3: middle estimate off by 1.1-fold (0.04 log units), on the low side; low and high end bracket the measured number.
By their numbers in this assay, from the lowest: compounds 2, 3 and 1 (each within the scatter of the next).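

In this assay, the two new steps, a 1.2-fold higher number from compound 2 to compound 3 (0.10 log units; within the scatter) and a 1.0-fold lower number from compound 1 to compound 3 (0.01 log units; within the scatter), both lie within the scatter, so the three groups on a saturated chain carbon bound to a saturated ring carbon now form one set with no measurable separation. Where the earlier compounds offered a single exchange at this place, this set adds a second and a third. The group with a five-membered aromatic ring with 1 hetero atom and a six-membered non-aromatic ring with 2 hetero atoms reads level both with the group whose six-membered ring is of carbon only and with the larger group of compound 1. Nothing available here accounts for why these groups read alike.

The compounds shown leave open whether a group of a different kind at this place, such as a carboxylic acid, a primary amine or an open diethylamino chain, would also stay within the scatter. They also leave open whether this assay would respond to a change elsewhere on the shared core, such as replacing the methoxy group with a hydroxyl group.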